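Changing the amine substituent on compound 2's piperazine ring

A few compounds are considered here, and "the series" means these few. Any claim that something is new, unique, unknown or untested is made for them only; others in the source may bear on it.

Measured compounds:
- compound 1, `CN(Cc1ccc(C2=NCCN2)cc1)C(=O)COCCN(C)S(=O)(=O)c1ccccc1C#N`, 87%
- compound 2, `COc1cc(C)c(S(=O)(=O)N(C)CCOCC(=O)N2CCN(C3CCN(C4CC4)CC3)CC2)c(C)c1`, 6%
- compound 3, `Cc1c(Cl)ccc(S(=O)(=O)N(C)CCC(=O)N(C)Cc2ccc(C3=NCCN3)cc2)c1Cl`, 5%

All three were tested in an ADME assay on microsomes from liver (Homo sapiens) for metabolic stability, with a stated time of 30 min, tested at 1 uM; on this read-out lower numbers stand for a less stable compound and higher numbers for a more stable compound. Compound 2 stands second of the three numbers. Its nearest neighbour is compound 3, whose value lies within the usual scatter of its own, so the two cannot be told apart. The furthest is compound 1, whose value lies far higher, well beyond the scatter.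

Compound 4, `COc1cc(C)c(S(=O)(=O)N(C)CCOCC(=O)N2CCN(CCN(C)C)CC2)c(C)c1`, has not yet been measured in this assay. It keeps the whole sulfonyl-aryl part and the ether-amide linker of compound 2 and differs in one place only: 2-(dimethylamino)ethyl in place of 1-cyclopropylpiperidin-4-yl on an amine nitrogen in a ring. The group that leaves carries two rings, the group that enters carries none, and both hold a single hydrogen-bond acceptor.

Going by the values given here, no pair of measured compounds shows this change, so there is no measured step to lean on. The retained part of compound 2 is shared with a compound that sits very low, and compound 3, which also sits low, shares the sulfonamide motif. The expected step of a number 6 percentage points higher from compound 2 to compound 4 (within the scatter) is therefore small and upward at most, quite possibly none beyond the scatter. Compound 4 is estimated at 12%, with a range from 3% to 40%.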

Compound 4, percent of the compound remaining: 84%
Compound 4: middle estimate off by 72 percentage points, on the low side, outside the stated range (above it).
By their numbers in this assay, from the lowest: compounds 3 and 2 (each within the scatter of the next); then compounds 4 and 1 (each within the scatter of the next).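

In this assay, placing 2-(dimethylamino)ethyl where 1-cyclopropylpiperidin-4-yl stood on the amine nitrogen in the ring gives a number 78 percentage points higher from compound 2 to compound 4 (beyond the scatter) and is the only difference between the two structures. This single position can therefore take a compound from the low end of this small set to the high end, and the sulfonyl-aryl part and the ether-amide linker, which compound 4 keeps, do not on their own hold the number down. The earlier compounds could not show this, as no two of them differed in only one place, and nothing measured here explains why this change has so large an effect.

The entering group differs from the leaving one in several ways at once, with no ring and fewer heavy atoms, so the compounds shown do not tell which of these differences matters. As far as these compounds go, a plain piperidin-4-yl without the cyclopropyl, or a longer 3-(dimethylamino)propyl chain, would help to separate them, and whether the same swap works with other sulfonyl-aryl parts remains open too.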